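Carbonyl substituent exchange on a shared core

The compounds below may be only part of what the source reports. "The series", "measured", "known", "first", "only" and "open" are said of these compounds alone.

Measured so far in an assay on LtK cells with ATP-sensitive inward rectifier potassium channel 11 (Homo sapiens) as the target; a lower number here means that less compound is needed, a higher number that more compound is needed for the effect:
compound 1, `CCCC(=O)Nc1c(C(O)(C(F)(F)F)C(F)(F)F)ccc2ccccc12`, gives 131 nM
compound 2, `O=C(NCCCCCCCl)Nc1c(C(O)(C(F)(F)F)C(F)(F)F)ccc2ccccc12`, gives 4840 nM

Compound 2 holds the highest of the two numbers in this assay. Its nearest neighbour is compound 1, and the two are separated by a 37-fold higher number from compound 1 to compound 2 (1.57 log units; beyond the scatter), a large step that lies beyond the scatter.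

Compound 3, `N#Cc1cccc(C(=O)Nc2c(C(O)(C(F)(F)F)C(F)(F)F)ccc3ccccc23)c1`, is not yet measured in this assay. It differs from compound 2 in one place: 3-cyanophenyl in place of (6-chlorohexyl)amino on a carbonyl carbon.

Going by the values given here, the only measured step that bears on this change is a 37-fold higher number from compound 1 to compound 2 (1.57 log units; beyond the scatter), in which the substituent on the same carbonyl carbon was exchanged and the number rose sharply. Compound 3 returns to a carbon substituent on that carbonyl, as in compound 1, though an aromatic one rather than a short chain, so the number is expected to fall again, without reaching compound 1 with certainty.

The estimate for compound 3 in this assay is 350 nM, expected to lie between 70 nM and 1800 nM. This estimate means an expected step of a 14-fold lower number from compound 2 to compound 3 (1.14 log units; beyond the scatter).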

Compound 3, half-maximal effective concentration: 12 nM
Beside the measured number, compound 3's estimate is 29-fold (1.46 log units) above it; the whole stated range lies above it.
By their numbers in this assay, from the lowest: compound 3; then compound 1; then compound 2.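

At the substituent on the carbonyl carbon, 3-cyanophenyl in place of (6-chlorohexyl)amino gives a 400-fold lower number from compound 2 to compound 3 (2.61 log units; beyond the scatter) in this assay, so the same place that raised the number in the earlier pair can also bring it down by a larger step. With 3-cyanophenyl in place of propyl, the result is an 11-fold lower number from compound 1 to compound 3 (1.04 log units; beyond the scatter); both compounds here carry carbon on the carbonyl, so the fall below the short chain appears without any change in the atom type attached there, and an aromatic substituent is now the lowest of the three in this series. No accompanying measurement accounts for either step.

The compounds shown do not separate the aromatic ring from the nitrile, a question that a plain phenyl or a pyridine ring on the same carbonyl would address. They also leave open whether the high number of compound 2 goes with the amino nitrogen or with the long chlorinated chain, which propylamino and a hexyl chain on carbon would tell apart.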